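This account rests on a few compounds, and the source may have more. Where it says the series, first, only, none or still open, it means among the compounds named here.

Compound 1 `CNC(=O)Nc1ccc(-c2nc(N3CC4CCC(C3)O4)c3cnn(CCN(C)C)c3n2)cc1`: 0.0833 h
Compound 2 `O=C(Nc1ccc(-c2nc(N3CC4CCC(C3)O4)c3cnn(C4CCC5(CC4)OCCO5)c3n2)cc1)Nc1cccnc1`: > 0.5 h, a limit
Compound 3 `O=C(Nc1ccncc1)Nc1ccc(-c2nc(N3CC4CCC(C3)O4)c3cnn(C4CCC5(CC4)OCCO5)c3n2)cc1`: > 0.5 h, a limit

Among the compounds with values here, in an in vitro ADME assay on microsomes (Mus musculus) for metabolic stability (a lower number here means that the compound disappears faster, a higher number that the compound lasts longer), compound 1 gives 0.0833 h, the only actual number in the set. Compound 2 gives > 0.5 h, which is a limit of the assay. Compound 3 gives > 0.5 h, again a limit. The value of compound 1 therefore lies short of the limit of > 0.5 h in this assay, at which 2 of the 3 values shown sit.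

Compound 4 `CCn1ncc2c(N3CC4CCC(C3)O4)nc(-c3ccc(NC(=O)NC)cc3)nc21` has not yet been measured. It departs from compound 1 by hydrogen in place of dimethylamino on a saturated chain carbon, two bonds along the chain from an aromatic nitrogen, so that 2-(dimethylamino)ethyl becomes ethyl. Within the data shown here, the one measured step, a step that the two limits leave unreadable from compound 2 to compound 3, concerns a different change and has no readable size, so it offers no guide here. With only compound 1 at 0.0833 h as an anchor, no shift beyond the usual scatter is expected in this assay, and the expected step is a 1.4-fold higher number from compound 1 to compound 4 (0.16 log units; within the scatter). For compound 4 the estimated half-life is 0.12 h, with an expected range from 0.06 h to 0.4 h.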

Compound 4, half-life: > 0.5 h
Compound 4: only a limit was reported (the forecaster's own chance of this, stated with the estimate: 10%); at least 4.1-fold (0.61 log units) between middle value and limit.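

In this assay, within the data shown here, the change of 2-(dimethylamino)ethyl to ethyl gives an at least 6.0-fold higher number from compound 1 to compound 4 (0.77 log units; beyond the scatter), the first step in the set that can be read, since the step between compound 2 and compound 3 cannot. It shows that this chain position matters for the half-life: removing dimethylamino alone, with the rest of compound 1 kept, is enough to move the result beyond the scatter. Only the lower bound of the step is known, and compound 4 now stands at the limit of the assay with compounds 2 and 3: the limit of > 0.5 h in this assay, at which 3 of the 4 values shown sit.

On these data alone, how far the half-life of compound 4 extends past that limit stays open. So does whether a methoxy group or a pyrrolidine in place of dimethylamino, or a longer chain such as propyl in place of ethyl, would give the same result.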